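Two anilides at the assay limit and a dechlorinated analogue

The source may report more compounds than this note shows. Statements on the series, on what has been measured and on what is new or still open speak of the compounds shown alone.

Of the compounds shown here, two have been measured in a functional assay on HCT-116 cells (Homo sapiens) for inhibition, read by MTT assay, with a stated time of 2 days; a higher number here means that more compound is tolerated, a lower number that less compound is tolerated. Compound 1 `Nc1ccccc1NC(=O)c1ccc(NCC(=O)Nc2cccc([N+](=O)[O-])c2)cc1` gives in this assay only a limit, not a number: > 100000 nM. Compound 2 `Nc1ccccc1NC(=O)CCCNCC(=O)Nc1cc(Cl)ccc1Cl` likewise gives in this assay only a limit: > 100000 nM. Compound 2 therefore stands where the whole measured set stands, at the ceiling of the assay with no number beneath it, as summarised by the limit of > 100000 nM in this assay, at which 2 of the 2 values shown sit. Within the data shown here, no step between measured compounds can be computed, since each of the two values is a limit rather than a number.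

Compound 3 `Nc1ccccc1NC(=O)CCCNCC(=O)Nc1ccc(Cl)cc1` differs from compound 2 in one place: 4-chlorophenyl in place of 2,5-dichlorophenyl on an amide-type nitrogen. Whether this change moves the read-out cannot be read from the measured pair, which sit at the same limit. The expected step from compound 2 to compound 3 is a step that the limit leaves unreadable from compound 2 to compound 3, that is, nothing beyond the scatter, with the result most likely reported once more as a limit. For compound 3 the estimated lethal concentration in this assay is 150000 nM, with a range from 50000 nM to 500000 nM.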

Compound 3, concentration lethal to 50% of the cells: > 100000 nM
Compound 3: no number, only a limit; the forecaster's own chance of this, stated with the estimate: 85%; the middle value does not contradict the limit.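

In this assay compound 3 gives only a limit, > 100000 nM. Among these compounds, no step from compound 2 to compound 3 can be read, so 4-chlorophenyl in place of 2,5-dichlorophenyl shows no readable effect: the limit of > 100000 nM in this assay, at which 3 of the 3 values shown sit. The compounds shown leave open whether any member of this series gives a number in this assay, and whether the group on the amide-type nitrogen matters there.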